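Adding a Second Chloro to Compound 2

The compounds below may be only part of what the source reports. "The series", "measured", "known", "first", "only" and "open" are said of these compounds alone.

Compound 1 `Cc1ccc(-c2cncc(OC[C@@H]3CCCN3C)c2)cc1` gives 0.13 nM in an assay on membranes from brain for binding affinity to Neuronal acetylcholine receptor; alpha4/beta2 (Rattus norvegicus); on this read-out lower numbers stand for stronger inhibition and higher numbers for weaker inhibition. Within the data shown here, compound 2 `CN1CCC[C@H]1COc1cncc(-c2ccc(Cl)cc2)c1` gives 0.082 nM in this assay, and the only measured step, a 1.6-fold lower number from compound 1 to compound 2 (0.20 log units; within the scatter), sits within the scatter, so compound 2 stands within the scatter of compound 1, the only other compound measured. Compound 3 `CN1CCC[C@H]1COc1cncc(-c2ccc(Cl)cc2Cl)c1` carries the change (chloro in place of hydrogen on an aromatic carbon). Among the measured compounds shown here, no measured step adds a chloro in place of hydrogen; the one step known, a 1.6-fold lower number from compound 1 to compound 2 (0.20 log units; within the scatter), exchanges one group for another and moved the number only slightly, which gives little ground for expecting a large shift here. Compound 3 is therefore expected to show no step beyond the scatter, with the estimated step being a 1.2-fold higher number from compound 2 to compound 3 (0.09 log units; within the scatter). The estimate for compound 3 in this assay is 0.1 nM, with a range from 0.03 nM to 0.4 nM.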

Compound 3, inhibition constant: 0.16 nM
For compound 3 the middle estimate is 1.6-fold (0.20 log units) below the measured one; low and high end bracket the measured number.
By their numbers in this assay, from the lowest: compounds 2, 1 and 3 (each within the scatter of the next).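

Among these compounds, compound 3 gives the first reading at this carbon, ortho to a large group and meta to a chloro group; the earlier step exchanged one group for another at a different place. In this assay, adding the chloro in place of hydrogen gives a 2.0-fold higher number from compound 2 to compound 3 (0.29 log units; within the scatter), so a second chloro on this ring is accommodated without a step beyond the scatter. Nothing at hand bears on why this change leaves the read-out within the scatter.

The compounds shown leave open whether groups other than chloro at this carbon, such as a methoxy group, an amine or a carboxylic acid, would also stay within the scatter. They also leave open how a chloro here would read with hydrogen in place of the existing chloro group.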